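Methoxy for bromo in compound 3

A few compounds are considered here, and "the series" means these few. Any claim that something is new, unique, unknown or untested is made for them only; others in the source may bear on it.

In an ADME assay on microsomes from liver (Rattus norvegicus) for metabolic stability (a lower number here means that the compound disappears faster, a higher number that the compound lasts longer), compound 1 (`Nc1nc(NCCNc2ncc(-c3ncc[nH]3)c(-c3ccc(F)cc3C(F)(F)F)n2)ccc1[N+](=O)[O-]`) gives > 0.5 h as a limit of the assay and not as a number. Compound 2 (`Nc1nc(NCCNc2ncc(-c3ncc[nH]3)c(-c3ccc(Cl)cc3Br)n2)ccc1[N+](=O)[O-]`) gives > 0.5 h as a limit too, so its place is known only as a limit. Going by the values given here, the one measured step that the two limits leave unreadable from compound 1 to compound 2 brings 2-bromo-4-chlorophenyl in place of 4-fluoro-2-(trifluoromethyl)phenyl and has no readable size. Beyond it there is only the limit of > 0.5 h in this assay, at which 2 of the 2 values shown sit, and this gives no size for any change.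

Compound 3 (`COc1cc(Cl)ccc1-c1nc(NCCNc2ccc([N+](=O)[O-])c(N)n2)ncc1-c1ncc[nH]1`) differs from compound 2 by methoxy in place of bromo on an aromatic carbon ortho to a large group. The step that the two limits leave unreadable from compound 1 to compound 2 offers no size to carry over, so no step beyond the scatter is expected in either direction in this assay and the expected move is a step that the limit leaves unreadable from compound 2 to compound 3 in size. Compound 3 is estimated at 0.8 h with an expected range from 0.3 h to 2 h. Compound 3 too may well end up with only a limit.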

Compound 3, half-life: > 0.5 h
Compound 3: a limit, no number; the forecaster's own chance of this, stated with the estimate: 70%; the middle value is on the limit's open side.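

In this assay compound 3 gives > 0.5 h, which is again a limit and not a number. No step between compound 1, compound 2 and compound 3 can be read, in size or in direction: the limit of > 0.5 h in this assay, at which 3 of the 3 values shown sit.

The compounds shown leave open how long each of the three actually lasts, and whether methoxy in place of bromo changes the half-life at all.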